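Adding a Nitro Group to Compound 3

The compounds below may be only part of what the source reports. "The series", "measured", "known", "first", "only" and "open" are said of these compounds alone.

Of the compounds shown here, three have so far been tested in a functional assay on the whole organism (strain Wistar Albino) for inhibition, with Rattus norvegicus as the target, read by paw edema, with a stated time of 3 h, at a dose of 20 mg/kg; on this read-out lower numbers stand for less inhibition and higher numbers for more inhibition at the one dose given (going by the name of the read-out). Compound 1 `Cc1cc(-c2nn3c(-c4ccoc4C)nnc3s2)c2ccccc2n1` gives 18.6% in this assay. Compound 2 `COc1ccc(Cc2nnc3n2NC(c2ccco2)S3)cc1OC` gives 21.1%. Compound 3 `Cc1occc1-c1nnc2n1NC(c1ccco1)S2` gives 24.1%, the highest of the three numbers, yet compound 2 sits only a few points lower and compound 1 a little further off, and both of those gaps lie within the usual scatter of repeated measurements, so the three cannot be ranked against one another.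

Compound 4 `Cc1occc1-c1nnc2n1NC(c1ccc([N+](=O)[O-])o1)S2` has not yet been measured. It differs from compound 3 in one place: nitro in place of hydrogen on an aromatic carbon. For the measured compounds named here, no two of the measured compounds differ from each other by a single change, so there is no measured step that shows what such an addition does in this setting.

Without such a step, the expectation for the change from compound 3 to compound 4 in this assay is a step of about a number 1.9 percentage points higher from compound 3 to compound 4 (within the scatter), which is to say no movement beyond the scatter in either direction. Compound 4 is therefore estimated to give 26%, with a likely range from 14% to 38%.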

Compound 4, a percentage reported as inhibition, in the whole organism at one dose (the size of the read-out at that dose, not a potency): 22.8%
Compound 4: the middle estimate sits 3.2 percentage points above what was measured, within the range that was stated.
By their numbers in this assay, from the lowest: compounds 1, 2, 4 and 3 (each within the scatter of the next).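

In this assay, for the compounds shown here, this is the first single change that can be read directly, and it gives a number 1.3 percentage points lower from compound 3 to compound 4 (within the scatter). Nitro in place of hydrogen, on this aromatic carbon of the five-membered aromatic ring with one oxygen, next to the ring oxygen, therefore leaves the read-out within the usual scatter of repeated measurements, even though the entering group brings three heavy atoms where there was only a hydrogen atom, so this position accepts that added bulk without a detectable gain or loss of inhibition at the one dose given. Nothing measured here accounts for why the number holds steady, so the result can be stated but not explained.

On these data alone, a single group at a single position says little about the position in general, so it stays open whether an amine, a carboxylic acid or a longer chain on the same carbon would also leave the read-out within the scatter or would move it beyond. As far as these compounds go, it also stays open whether nitro would give a similar step on compound 2, whose other parts differ from those of compound 3.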